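Trifluoromethyl in Place of Chloro on a Pyrimidine-Free Core

The source may report more compounds than this note shows. Statements on the series, on what has been measured and on what is new or still open speak of the compounds shown alone.

Measured compounds in an assay on Jurkat cells for activation of nuclear factor NF-kappa-B complex (Homo sapiens); a lower number here means a stronger inhibitor, a higher number a weaker inhibitor:
- compound 1 `O=C(Nc1cc(C(F)(F)F)cc(C(F)(F)F)c1)c1cnc(Cl)nc1`: 300 nM
- compound 2 `O=C(Nc1cc(C(F)(F)F)cc(C(F)(F)F)c1)c1cnc(Cl)nc1-c1cccs1`: 9800 nM
- compound 3 `CCCc1nc(Cl)ncc1C(=O)Nc1cc(C(F)(F)F)cc(C(F)(F)F)c1`: 500 nM

Compound 1 has the lowest number of the three. Compound 3 sits close to it, a 1.7-fold higher number from compound 1 to compound 3 (0.22 log units; within the scatter), while compound 2 lies far off, a 33-fold higher number from compound 1 to compound 2 (1.51 log units; beyond the scatter); the return, a 20-fold lower number from compound 2 to compound 3 (1.29 log units; beyond the scatter), is equally large. Compound 4 `O=C(Nc1cc(C(F)(F)F)cc(C(F)(F)F)c1)c1cnc(C(F)(F)F)nc1` differs from compound 1 by trifluoromethyl in place of chloro on an aromatic carbon. Among the compounds with values here, no measured step touches this place: all three measured steps concern a different aromatic carbon of the shared core, so nothing here shows how the site between two ring nitrogen atoms responds. Chloro and trifluoromethyl are both small, uncharged groups, and the rest of compound 4 is unchanged, so the expected step of a 1.3-fold higher number from compound 1 to compound 4 (0.12 log units; within the scatter) is small and not clearly beyond the scatter in either direction. Compound 4 is therefore estimated at 400 nM, with a range from 100 nM to 1600 nM in this assay.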

Compound 4, half-maximal inhibitory concentration: > 10000 nM
Compound 4 gave a limit, no number (the forecaster's own chance of this, stated with the estimate: 5%); middle value at least 25-fold (1.39 log units) away from the limit.
By their numbers in this assay, from the lowest: compounds 1 and 3 (each within the scatter of the next); then compound 2. At a limit, above all of these: compound 4.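

In this assay, the site between two ring nitrogen atoms proves sensitive: trifluoromethyl in place of chloro gives an at least 33-fold higher number from compound 1 to compound 4 (1.52 log units; beyond the scatter). Compound 4 gives a limit of the assay, not a number: the limit of > 10000 nM in this assay, at which 1 of the 4 values shown sits. Within the data shown here, the earlier steps all concerned a different aromatic carbon, so this is the first reading of this site, and it shows that one exchange of chloro here costs heavily.

Only chloro and trifluoromethyl appear at this site among the compounds shown. Going by these compounds, how an amine, a methoxy group or a plain hydrogen would fare there remains open.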